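Swapping a Pyrrolidine for a Bicyclic Diamine in an MCH1 Antagonist

The compounds below may be only part of what the source reports. "The series", "measured", "known", "first", "only" and "open" are said of these compounds alone.

Measured compounds:
compound 1, `N#Cc1cccc([C@]23CC[C@@H](N(CCCN4CC[C@@H](O)C4)C(=O)Nc4ccc(F)c(Cl)c4)[C@H]2C3)c1`, 22 nM
compound 2, `NCc1ncc([C@]23CC[C@@H](N(CCN4CCCC4)C(=O)Nc4ccc(F)c(C(F)(F)F)c4)C2C3)s1`, 107 nM

In a functional assay for antagonist activity at melanin-concentrating hormone receptor 1 (Homo sapiens) (on this read-out higher numbers stand for weaker inhibition and lower numbers for stronger inhibition), compound 2 gives 107 nM, the higher of the two numbers seen so far. Compound 1 gives 22 nM in this assay, a gap described as beyond the scatter, so compound 1 is the stronger inhibitor of the pair.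

Compound 3, `NCc1ncc([C@]23CC[C@@H](N(CCCN4CC5CC4CN5)C(=O)Nc4ccc(F)c(C(F)(F)F)c4)C2C3)s1`, has not yet been measured. It differs from compound 2 in one place: a group of 8 heavy atoms (6 carbon, 2 nitrogen; 2 five-membered non-aromatic rings with 1 hetero atom each) in place of a group of 5 heavy atoms (4 carbon, 1 nitrogen; one five-membered non-aromatic ring with 1 hetero atom), on a saturated chain carbon, two bonds along the chain from an amide-type nitrogen. Going by the values given here, no measured pair shows exactly this exchange, so the size of the step can only be guessed. The added ring and hydrogen-bond donor are a moderate change at a site some distance from the shared core, so only a small step is expected, if any, and it is estimated to point toward a lower number, as a 1.8-fold lower number from compound 2 to compound 3 (0.25 log units; within the scatter). Compound 3 is therefore expected to give about 60 nM in this assay, within a range from 20 nM to 200 nM.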

Compound 3, inhibition constant: 73 nM
For compound 3 the middle estimate is 1.2-fold (0.09 log units) below the measured one; measured number inside the range.
By their numbers in this assay, from the lowest: compound 1; then compounds 3 and 2 (each within the scatter of the next).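

In this assay, exchanging the pyrrolidin-1-yl group for the larger diamine with two five-membered rings gives a 1.5-fold lower number from compound 2 to compound 3 (0.17 log units; within the scatter), so the two compounds cannot be told apart on this read-out. This place, on a saturated chain carbon two bonds along the chain from an amide-type nitrogen, therefore accepts a bigger group carrying a hydrogen-bond donor with no change beyond the scatter. No measurement offered here gives a reason for this result.

Going by these compounds, whether a piperazine or a morpholine at this place would also stay within the scatter remains open. The added ring and the hydrogen-bond donor also enter together in this single step, so their separate contributions cannot be read from these compounds.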